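The source may hold more compounds than are shown below. What is called first, only, known or untested is meant among the compounds shown, and "the series" means these compounds.

Compound 1 `COc1cccc2c1CCC2c1ncc[nH]1` gives 65% in a functional assay on CHO cells for agonist activity at Alpha-1A adrenergic receptor (Homo sapiens), read by FLIPR and calcium flux; on this read-out lower numbers stand for smaller maximal responses and higher numbers for larger maximal responses.
Compound 2 `Cc1oncc1-c1cccc2c1CCC2c1ncc[nH]1` gives 63%.
Compound 3 `Cn1cc(-c2cccc3c2CCC3c2ncc[nH]2)cn1` gives 12%.

Compound 3 stands lowest of the three: its nearest neighbour is compound 2, with a number 51 percentage points lower from compound 2 to compound 3 (beyond the scatter), and compound 1 lies furthest, with a number 53 percentage points lower from compound 1 to compound 3 (beyond the scatter). The step to compound 4 `c1cc(-c2nccs2)c2c(c1)C(c1ncc[nH]1)CC2` again exchanges the group on the aromatic carbon: 1,3-thiazol-2-yl in place of 1-methyl-1H-pyrazol-4-yl on an aromatic carbon. For the measured compounds named here, two measured steps bear on such an exchange. a number 2 percentage points lower from compound 1 to compound 2 (within the scatter) shows one five-membered heteroaryl leaving the response where methoxy had it, while a number 51 percentage points lower from compound 2 to compound 3 (beyond the scatter) shows another lowering it sharply. Neither involves a 1,3-thiazol-2-yl, so the outcome is uncertain. For compound 4 a step of a number 28 percentage points higher from compound 3 to compound 4 (beyond the scatter) is estimated, an expected partial return toward the higher values. Compound 4 is therefore expected at 40%, within 10% to 70%.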

Compound 4, largest response reached (Emax), in percent of the reference or control that the assay uses: 64%
Beside the measured number, compound 4's estimate is 24 percentage points below it; low and high end bracket the measured number.
By their numbers in this assay, from the lowest: compound 3; then compounds 2, 4 and 1 (each within the scatter of the next).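

In this assay, 1,3-thiazol-2-yl on this aromatic carbon brings the response back from the low number of 1-methyl-1H-pyrazol-4-yl, a number 52 percentage points higher from compound 3 to compound 4 (beyond the scatter), so that low number does not hold for every five-membered aromatic ring with 2 hetero atoms here. The same group stands level with the other two, a number 1 percentage points higher from compound 2 to compound 4 (within the scatter) and a number 1 percentage points lower from compound 1 to compound 4 (within the scatter), leaving compound 3 alone at the low end of the four. Nothing shown gives a cause for this gap between the two rings.

As far as these compounds go, whether 1H-pyrazol-4-yl without its methyl, an amine or a carboxylic acid on this carbon would keep the response stays open.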